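The compounds below may be only part of what the source reports. "The series", "measured", "known", "first", "only" and "open" are said of these compounds alone.

Measured so far in a functional assay on MCF7 cells (Homo sapiens) for antiproliferative activity, read by MTT assay, with a stated time of 48 h; a lower number here means a stronger inhibitor, a higher number a weaker inhibitor:
- compound 1 `COc1ccc(-c2c(Nc3cccc(C(F)(F)F)c3)c3ccccc3oc2=O)cc1`: 21600 nM
- compound 2 `COc1ccc(-c2c(Nc3ccc(C)cc3)c3ccc(O)cc3oc2=O)cc1`: 85500 nM
- compound 3 `COc1ccc(-c2c(Nc3ccc(NC(C)=O)cc3)c3ccc(O)cc3oc2=O)cc1`: > 100000 nM (a limit of the assay, not a number)

Compound 3 gives > 100000 nM in this assay, and this is a limit of the assay, not a number. Its place in the series is therefore known only as the limit of > 100000 nM in this assay, at which 1 of the 3 values shown sits.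

Compound 4 `COc1ccc(-c2c(Nc3cccc(C(F)(F)F)c3)c3ccc(O)cc3oc2=O)cc1` keeps the core of compound 3 and carries 3-(trifluoromethyl)phenyl in place of 4-acetamidophenyl on a nitrogen on an aromatic ring.

Among the measured compounds shown here, only one measured step links compounds with this core: acetamido in place of methyl on an aromatic carbon, an at least 1.1-fold higher number from compound 2 to compound 3 (0.06 log units; that floor lies within the scatter). That step involves other groups, so it gives no size for this change. The closest guide is compound 1, which carries the same 3-(trifluoromethyl)phenyl on a different core and gives 21600 nM. Its number is lower than that of compound 2 at 85500 nM.

On the strength of compound 1 at 21600 nM, a moderate move to a lower number is expected in this assay, though the different core leaves this uncertain. The expected change is an at least 2.5-fold lower number from compound 3 to compound 4 (0.39 log units; beyond the scatter).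

For compound 4 the estimated value is 40000 nM, with an expected range of 15000 nM to 100000 nM.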

Compound 4, half-maximal inhibitory concentration: 49100 nM
The estimate for compound 4 lay 1.2-fold (0.09 log units) below the measured number; the measured number falls inside the stated range.
By their numbers in this assay, from the lowest: compound 1; then compounds 4 and 2 (each within the scatter of the next). At a limit, above all of these: compound 3.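

The value of compound 3 is a limit of the assay, not a number: the limit of > 100000 nM in this assay, at which 1 of the 4 values shown sits. In this assay, 3-(trifluoromethyl)phenyl on this nitrogen therefore gives only a floor against 4-acetamidophenyl, an at least 2.0-fold lower number from compound 3 to compound 4 (0.30 log units; that floor lies within the scatter), while the comparison with 4-methylphenyl, a 1.7-fold lower number from compound 2 to compound 4 (0.24 log units; within the scatter), does not separate the two groups. The clearest new information concerns the other place on the core: with 3-(trifluoromethyl)phenyl kept on the nitrogen, hydroxy in place of hydrogen on an aromatic carbon gives a 2.3-fold higher number from compound 1 to compound 4 (0.36 log units; beyond the scatter), a modest step and the only one of the three that lies beyond the scatter.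

Going by these compounds, that hydroxy step rests on a single pair, and whether it holds with 4-methylphenyl or 4-acetamidophenyl on the nitrogen remains open. Also open, on these data alone, is how this assay would read with an amine or a carboxylic acid in place of the hydroxy, or with a chloro group in place of the trifluoromethyl.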